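Tolyl-type sulfonyl in place of difluorophenyl on a shared core

The source may hold more compounds than are shown below. What is called first, only, known or untested is meant among the compounds shown, and "the series" means these compounds.

Measured so far:
Compound 1, `COc1cccc(-c2c(S(=O)(=O)c3ccc(C)c(F)c3)cnc3c(F)cccc23)c1`: 4.02 mL/min
Compound 2, `O=S(=O)(c1cc(F)cc(F)c1)c1cnc2c(F)cccc2c1-c1ccc(Cl)cc1`: 0.73 mL/min

Two compounds of this series have been through an ADME assay on microsomes from liver (Homo sapiens) for metabolic stability, tested at 2.5 uM; on this read-out lower numbers stand for slow clearance and higher numbers for fast clearance. Compound 1 gives 4.02 mL/min, whereas compound 2 gives 0.73 mL/min, the lowest of the two numbers; the gap between them lies beyond the usual scatter. The two differ in more than one place, so what lies behind that gap cannot be assigned to either change alone.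

Compound 3, `Cc1ccc(S(=O)(=O)c2cnc3c(F)cccc3c2-c2ccc(Cl)cc2)cc1F`, has not yet been measured. Relative to compound 2 it carries 3-fluoro-4-methylphenyl in place of 3,5-difluorophenyl on a sulfonyl sulfur, while everything else on the shared core stays as it was. Compound 3 therefore shares its sulfonyl substituent with compound 1 and the rest of its structure with compound 2.

For the step from compound 2 to compound 3 in this assay, an increase is expected, estimated at a 2.6-fold higher number from compound 2 to compound 3 (0.42 log units; beyond the scatter), because compound 1, which carries the same sulfonyl substituent, gives 4.02 mL/min. Compound 3 is accordingly expected to give about 1.9 mL/min, within a range from 0.8 mL/min to 4.5 mL/min.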

Compound 3, intrinsic clearance in a liver preparation (reported as CLH), per the amount of preparation that the assay uses: 2.2 mL/min
The estimate for compound 3 lay 1.2-fold (0.06 log units) below the measured number, within the range that was stated.
By their numbers in this assay, from the lowest: compound 2; then compounds 3 and 1 (each within the scatter of the next).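

In this assay, replacing 3,5-difluorophenyl with 3-fluoro-4-methylphenyl on the sulfonyl sulfur, with everything else on the shared core unchanged, gives a 3.0-fold higher number from compound 2 to compound 3 (0.48 log units; beyond the scatter) and thus isolates a change at this position that lies beyond the scatter, which the two earlier compounds, differing in more than one place, could not do. The other single change, 4-chlorophenyl in place of 3-methoxyphenyl on an aromatic carbon, gives a 1.8-fold lower number from compound 1 to compound 3 (0.26 log units; within the scatter) and stays within the scatter, so with the 3-fluoro-4-methylphenyl sulfonyl substituent in place, compound 1 and compound 3 cannot be told apart on this read-out. No measurement shown here bears on why the sulfonyl exchange gives this step.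

The compounds shown leave open whether the same exchange would give a step of similar size with 3-methoxyphenyl on the core, and whether the step follows the added methyl group or the fluorine that is gone. They also leave open how the read-out would respond to a sulfonyl-bound phenyl ring carrying a nitrile or an amine.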